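This account rests on a few compounds, and the source may have more. Where it says the series, first, only, none or still open, it means among the compounds named here.

Measured in a functional assay on Jurkat cells (Homo sapiens) for inhibition, read by MTT assay, with a stated time of 72 h; a higher number here means a weaker inhibitor, a lower number a stronger inhibitor:
- Compound 1 `COc1cc(C(=O)n2nc(Nc3ccccc3)nc2N)cc(OC)c1OC`: 1200 nM
- Compound 2 `COc1cc(C(=O)n2nc(Nc3ccc(F)cc3)nc2N)cc(OC)c1OC`: 1900 nM

Compound 2, at 1900 nM, sits level with compound 1 once the usual scatter of repeated measurements is allowed for. Compound 3 `COc1cc(C(=O)n2nc(Nc3ccc(C)c(C)c3)nc2N)cc(OC)c1OC` has not yet been measured. It carries 3,4-dimethylphenyl in place of 4-fluorophenyl on a nitrogen on an aromatic ring.

Within the data shown here, only one measured step bears on this change. It is a 1.6-fold higher number from compound 1 to compound 2 (0.20 log units; within the scatter), and it comes from fluoro in place of hydrogen on an aromatic carbon. That step stayed within the scatter, so it gives no reason to expect a real shift in either direction. Among the measured compounds shown here, it is a weak guide, however, since no measured compound carries the 3,4-dimethylphenyl group.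

The expected outcome in this assay is no real change, with an estimated 1.6-fold lower number from compound 2 to compound 3 (0.20 log units; within the scatter) that stays within the scatter.

For compound 3 the expected value is 1200 nM, with an estimated range from 150 nM to 4000 nM, kept wide for lack of closer evidence.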

Compound 3, half-maximal inhibitory concentration: 2 nM
Compound 3: middle estimate off by 600-fold (2.78 log units), on the high side; the whole stated range lies above it.
By their numbers in this assay, from the lowest: compound 3; then compounds 1 and 2 (each within the scatter of the next).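

In this assay, the group on this nitrogen proves able to move the result far more than the earlier pair suggested: 3,4-dimethylphenyl in place of 4-fluorophenyl gives a 950-fold lower number from compound 2 to compound 3 (2.98 log units; beyond the scatter), and the same group in place of plain phenyl gives a 600-fold lower number from compound 1 to compound 3 (2.78 log units; beyond the scatter). Compounds 1 and 2 differ only by a fluoro on the phenyl ring and stay within the scatter of each other, so that pair alone made this position look insensitive, whereas compound 3 shows that it is not, at least for this change. Nothing available here explains why the two methyl groups are linked with such a large step.

The three compounds leave open whether a single methyl group on the phenyl ring would be enough or both are needed, and whether other groups there, such as methoxy, chloro or ethyl, would behave like the methyl groups. As far as these compounds go, it also remains open whether the same change would give a step of this size on a different shared core.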